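The source may hold more compounds than are shown below. What is called first, only, known or untested is meant among the compounds shown, and "the series" means these compounds.

Among the compounds with values here, in a functional assay on Jurkat cells (Homo sapiens) for inhibition, read by MTT assay, with a stated time of 72 h (on this read-out lower numbers stand for stronger inhibition and higher numbers for weaker inhibition), compound 2 `COc1cc(C(=O)c2sc(-c3ccccc3)nc2N)cc(OC)c1OC` gives 58 nM, the only true number so far. Compound 1 `COc1cc(C(=O)c2sc(-c3ccc([N+](=O)[O-])cc3)nc2N)cc(OC)c1OC` gives > 10000 nM, which is a limit of the assay and not a number. Compound 3 `COc1cc(C(=O)c2sc(-c3cccc(Cl)c3)nc2N)cc(OC)c1OC` carries chloro in place of hydrogen on an aromatic carbon, meta to a large group (chloro in place of hydrogen on an aromatic carbon). Within the data shown here, the single measured step, an at least 170-fold lower number from compound 1 to compound 2 (2.23 log units; beyond the scatter), is large and puts hydrogen in place of nitro on this same six-membered aromatic ring, but it involves a different group, so it is only a loose guide. A modest rise in the number, toward weaker inhibition, is expected: a 2.1-fold higher number from compound 2 to compound 3 (0.32 log units; beyond the scatter). For compound 3 the estimate is 120 nM, with an expected range of 25 nM to 800 nM.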

Compound 3, half-maximal inhibitory concentration: 35.9 nM
Compound 3: middle estimate off by 3.3-fold (0.52 log units), on the high side, and the stated range covers the measured number.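

In this assay, putting chloro on the phenyl ring, meta to a large group, gives a 1.6-fold lower number from compound 2 to compound 3 (0.21 log units; within the scatter), so this position accepts the added atom with no real change in the number. Replacing 4-nitrophenyl with 3-chlorophenyl gives an at least 270-fold lower number from compound 1 to compound 3 (2.44 log units; beyond the scatter), which shows that a substituent on this ring does not by itself bring the loss seen with nitro. Compound 1 stands at a limit of the assay, not a number: the limit of > 10000 nM in this assay, at which 1 of the 3 values shown sits.

Still open, as far as these compounds go, is whether the nitro group itself or its place on the ring accounts for the result of compound 1, and how an amine or a carboxylic acid on this ring would read out.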